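The compounds below may be only part of what the source reports. "The series", "measured", "known", "first", "only" and "open" are said of these compounds alone.

Measured compounds:
- compound 1, `CCCCCCCCCCCCCCNC(=O)[C@H](CO)/N=C/c1cccc(C)c1`: 51100 nM
- compound 2, `CCCCCCCCCCCCCCNC(=O)[C@H](CO)/N=C/c1cccc([N+](=O)[O-])c1`: 82700 nM
- compound 3, `CCCCCCCCCCCCCCNC(=O)[C@H](CO)/N=C/c1ccc([N+](=O)[O-])cc1`: 49500 nM

All three were read in an ADME assay on HEK293 cells (Homo sapiens) for cytotoxicity; on this read-out lower numbers stand for stronger inhibition and higher numbers for weaker inhibition. The numbers sit close together. Compound 2 and compound 1 differ by methyl in place of nitro on an aromatic carbon, and this gave a 1.6-fold lower number from compound 2 to compound 1 (0.21 log units; within the scatter). Compound 2 and compound 3 differ by 4-nitrophenyl in place of 3-nitrophenyl on a carbon with a double bond to nitrogen, which gave a 1.7-fold lower number from compound 2 to compound 3 (0.22 log units; within the scatter). Compound 1 and compound 3 show a 1.0-fold lower number from compound 1 to compound 3 (0.01 log units; within the scatter).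

Compound 4, `CCCCCCCCCCCCCCNC(=O)[C@H](CO)/N=C/c1ccc(C)cc1`, has not yet been measured. It differs from compound 3 by methyl in place of nitro on an aromatic carbon. For the measured compounds named here, this is the same kind of change as the one from compound 2 to compound 1, but not the same: there the place is meta to a large group, here it is para to a large group. The cores of compound 3 and compound 2 differ as described under (4-nitrophenyl in place of 3-nitrophenyl on a carbon with a double bond to nitrogen).

Given that the earlier step of this kind was a 1.6-fold lower number from compound 2 to compound 1 (0.21 log units; within the scatter), compound 4 is expected to give roughly a 1.2-fold lower number from compound 3 to compound 4 (0.07 log units; within the scatter) in this assay. The estimate for compound 4 is 42000 nM, with a range from 20000 nM to 90000 nM expected.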

Compound 4, half-maximal inhibitory concentration: 47300 nM
Compound 4: middle estimate off by 1.1-fold (0.05 log units), on the low side, and the stated range covers the measured number.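

In this assay, methyl in place of nitro on an aromatic carbon gives steps on the two cores that do not differ beyond the scatter: the same change on two cores in this assay, a 1.6-fold lower number (0.21 log units; within the scatter) from compound 2 to compound 1 and a 1.0-fold lower number (0.02 log units; within the scatter) from compound 3 to compound 4, 1.5-fold (0.19 log units) apart, within the scatter of two such steps Set beside this, a 1.0-fold lower number from compound 3 to compound 4 (0.02 log units; within the scatter), a 1.7-fold lower number from compound 2 to compound 4 (0.24 log units; within the scatter) and a 1.1-fold lower number from compound 1 to compound 4 (0.03 log units; within the scatter) are all small steps, so no order can be drawn among compound 1, compound 2, compound 3 and compound 4. For the compounds shown here, the agreement shows only that the change stays within the scatter on both cores; it does not show a real effect that carries from one core to another, and two cores with only nitro and methyl as substituents cannot support a rule for the series.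

On these data alone, it remains open whether an amine or a carboxylic acid on the aromatic ring would move the number beyond the scatter. The same question stands for a shorter chain in place of the long chain on the amide nitrogen, which all four compounds share.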